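The source may report more compounds than this note shows. Statements on the series, on what has been measured and on what is new or still open speak of the compounds shown alone.

The measured compounds:

Compound 1 `C=CCOC(=O)Nc1ccc([Se]C#N)cc1`; in an ADME assay on 184B5 cells (Homo sapiens) for cytotoxicity, read by MTT assay, with a stated time of 72 h (a higher number here means a weaker inhibitor of growth, a lower number a stronger inhibitor of growth), compound 1 gives 9800 nM.
Compound 2 `CCCOC(=O)Nc1ccc([Se]C#N)cc1`; in this assay compound 2 gives 9100 nM.
Compound 3 `O=C(Nc1ccc([Se][Se]c2ccc(NC(=O)OCc3ccc([N+](=O)[O-])cc3)cc2)cc1)OCc1ccc([N+](=O)[O-])cc1`; in this assay compound 3 gives 13800 nM.

Compound 2 holds the lowest of the three numbers in this assay, but both other compounds lie within the scatter of it, so no ordering among the three can be drawn. The unmeasured compound 4 `CCOC(=O)Nc1ccc([Se]C#N)cc1` differs from compound 2 in one place: hydrogen in place of methyl on a saturated chain carbon, two bonds along the chain from an oxygen next to a carbonyl group. Within the data shown here, the only measured step that bears on this change sits on the same saturated chain bound to the oxygen next to the carbonyl group: a 1.1-fold lower number from compound 1 to compound 2 (0.03 log units; within the scatter). That step, ethyl in place of vinyl, left the number essentially unchanged, and the step to compound 4, propyl to ethyl, is a similar small trimming of the same chain. The step is therefore expected to be a 1.0-fold higher number from compound 2 to compound 4 (0.02 log units; within the scatter), no shift beyond the scatter in either direction. Compound 4 is estimated at 9500 nM, within a range of 5000 nM to 18000 nM.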

Compound 4, concentration for total growth inhibition: 18600 nM
Compound 4: the middle estimate sits 2.0-fold (0.29 log units) below what was measured; the measured number lies above the stated range.
By their numbers in this assay, from the lowest: compounds 2, 1, 3 and 4 (each within the scatter of the next, the first and the last beyond it).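

In this assay, among these compounds, the change from propyl to ethyl gives the only step along this chain that passes beyond the scatter (a 2.0-fold higher number from compound 2 to compound 4 (0.31 log units; beyond the scatter)), though it is a modest one. Removing a single methyl at this place, on a saturated chain carbon two bonds along the chain from an oxygen next to a carbonyl group, therefore does register, whereas exchanging vinyl for ethyl does not (a 1.1-fold lower number from compound 1 to compound 2 (0.03 log units; within the scatter)). The reading is not firm, since replacing vinyl with methyl at the neighbouring chain carbon stays within the scatter (a 1.9-fold higher number from compound 1 to compound 4 (0.28 log units; within the scatter)).

Nothing available accounts for the shift. Going by these compounds, whether a longer chain such as butyl, a branched chain such as isopropyl, or a terminal amine would move the number in either direction remains open.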